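The source may hold more compounds than are shown below. What is called first, only, known or untested is meant among the compounds shown, and "the series" means these compounds.

Compound 3 `C[C@@H](O)[C@H](NC(=O)CN(c1ncnc2c1ncn2C1CCCCO1)C1CC1)C(=O)OCc1ccccc1` stands lowest of the three numbers gathered so far. In a functional assay on the whole organism (Tail, strain ICR) with Mus musculus as the target, in the tail flick test, with a stated time of 120 min, at a dose of 25 umol/kg by the oral route (a higher number here means a stronger effect of the compound at the dose given, a lower number a weaker effect), compound 3 gives 10.9%, while compound 1 `CC[C@H](C)[C@H](NC(=O)CN(c1nc(Cl)nc2[nH]cnc12)C1CC1)C(=O)O` gives 21.4% and compound 2 `O=C(CN(c1nc(Cl)nc2[nH]cnc12)C1CC1)N[C@@H](CCC(=O)OCc1ccccc1)C(=O)OCc1ccccc1` gives 45.9%; both of these sit above compound 3 by gaps beyond the scatter, compound 2 by the wider one. Compound 4 `CC(C)C[C@H](NC(=O)CN(c1ncnc2c1ncn2C1CCCCO1)C1CC1)C(=O)OCc1ccccc1` has not yet been measured. It differs from compound 3 in a single place: isobutyl in place of 1-hydroxyethyl on a saturated chain carbon bound to an amide-type nitrogen and a carbonyl carbon. For the measured compounds named here, no pair of measured compounds shows this same change, so the expectation can rest only on the spread of the three measured numbers and on the nature of the change itself. Compound 4 is expected to give 20% in this assay, with a range from 5% to 40%. The estimated step of a number 9.1 percentage points higher from compound 3 to compound 4 (within the scatter) is expected to point upward but to reach only to about the edge of the scatter, since the three measured numbers give no firm ground for a larger move in either direction.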

Compound 4, a percentage reported as activity, at one dose (the size of the read-out at that dose, not a potency): 12.8%
Compound 4: middle estimate off by 7.2 percentage points, on the high side, within the range that was stated.
By their numbers in this assay, from the lowest: compounds 3, 4 and 1 (each within the scatter of the next, the first and the last beyond it); then compound 2.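

Isobutyl in place of 1-hydroxyethyl on a saturated chain carbon bound to an amide-type nitrogen and a carbonyl carbon gives, in this assay, a number 1.9 percentage points higher from compound 3 to compound 4 (within the scatter), so this first direct reading of the position leaves the two compounds indistinguishable. On this pair, exchanging a group with one hydrogen-bond donor and one acceptor for a group with neither produces no difference beyond the scatter at the single dose and time given. No evidence is available on why the two compounds read alike.

From the compounds shown here alone, whether an amine on this carbon, such as a 4-aminobutyl chain, or a longer alkyl chain such as n-hexyl, would separate from these two remains open. Also open, going by these compounds, is whether the same exchange would read alike at another dose or time.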